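The compounds below may be only part of what the source reports. "The series", "measured", "known", "first", "only" and "open" are said of these compounds alone.

Within the data shown here, of the three compounds measured so far, compound 3 `COc1cc2c(cc1OC)C(CC(=O)N1CCNCC1)CC2` stands highest: in a functional assay on the whole organism (strain Wistar) for inhibition, with Rattus norvegicus as the target, read by paw edema, with stated times of 60 min and 3 h, at a dose of 100 mg/kg by the oral route (a lower number here means less inhibition, a higher number more inhibition at the dose given (going by the name of the read-out)), compound 3 gives 42%. Compound 1 `CNC(=O)CC1CCc2cc(OC)c(OC)cc21` gives 29% in this assay, and compound 2 `CCCNC(=O)CC1CCc2cc(OC)c(OC)cc21` gives 29%. Between the two secondary amides there is no change at the digits printed from compound 1 to compound 2 (within the scatter). Exchanging either of them for the piperazine amide brings a rise: a number 13 percentage points higher from compound 1 to compound 3 (beyond the scatter) and likewise a number 13 percentage points higher from compound 2 to compound 3 (beyond the scatter).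

Compound 4 `COc1cc2c(cc1OC)C(CC(=O)NCCO)CC2` is the next step from compound 3, and the change is (2-hydroxyethyl)amino in place of piperazin-1-yl on a carbonyl carbon. This change runs in the opposite direction to the two steps that bear on it: the move from a secondary amide to the piperazine amide was worth a number 13 percentage points higher from compound 1 to compound 3 (beyond the scatter) and a number 13 percentage points higher from compound 2 to compound 3 (beyond the scatter), so returning to a secondary amide, now one carrying a hydroxyl on the chain, is expected to give back a part or the whole of that gain. The expected step is therefore a number 10 percentage points lower from compound 3 to compound 4 (within the scatter). For compound 4 the estimate in this assay is 32%, with a range from 20% to 45%.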

Compound 4, a percentage reported as inhibition, in the whole organism at one dose (the size of the read-out at that dose, not a potency): 12.3%
Compound 4: middle estimate off by 19.7 percentage points, on the high side; the measured number lies below the stated range.
By their numbers in this assay, from the lowest: compound 4; then compounds 1 and 2 (each within the scatter of the next); then compound 3.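

At this carbonyl carbon, a secondary amide is not a uniform choice: in this assay, the (2-hydroxyethyl)amino group loses more than the gain piperazin-1-yl had brought over the simple chains (a number 29.7 percentage points lower from compound 3 to compound 4 (beyond the scatter)). It also falls short of both simple secondary amides, with a hydroxy in place of the methyl of the propyl chain (a number 16.7 percentage points lower from compound 2 to compound 4 (beyond the scatter)) and a hydroxymethyl in place of a hydrogen of the methyl group (a number 16.7 percentage points lower from compound 1 to compound 4 (beyond the scatter)), whereas the step from methyl to propyl had changed nothing. No available measurement gives a reason for this drop.

Going by these compounds, it remains open whether the hydroxyl itself or its place on the chain governs the result, which a methoxyethyl or a 3-hydroxypropyl amide could test. A morpholine or piperidine amide could likewise show whether the piperazine result depends on its second ring nitrogen.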